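This account rests on a few compounds, and the source may have more. Where it says the series, first, only, none or still open, it means among the compounds named here.

Compound 3 `FC(F)(F)c1cncc(Cc2ccc(-c3ccccc3)nc2)c1` gives 1120 nM in an in vitro assay on V79MZh cells for inhibition of cytochrome P450 11B2, mitochondrial (Homo sapiens) (on this read-out higher numbers stand for weaker inhibition and lower numbers for stronger inhibition), the highest number of the three measured. Compound 2 `c1ccc(-c2ccc(Cc3cccnc3)cn2)cc1` gives 322 nM and compound 1 `c1ccc(-c2ccc(C(c3ccccc3)n3ccnc3)cn2)cc1` gives 110 nM. For the measured compounds named here, the only step so far at this position is a 3.5-fold higher number from compound 2 to compound 3 (0.54 log units; beyond the scatter). Compound 4 `c1ccc(-c2cncc(Cc3ccc(-c4ccccc4)nc3)c2)cc1` differs from compound 3 by phenyl in place of trifluoromethyl on an aromatic carbon, on an aromatic carbon of a six-membered aromatic ring with one nitrogen, two atoms from the ring nitrogen and meta to a large group. Going by the values given here, no measured step puts phenyl at this carbon; the only bearing is that compound 2 322 nM shows this carbon tolerates a small substituent with modest loss. A moderate fall, back toward compound 2, is expected: a 2.2-fold lower number from compound 3 to compound 4 (0.35 log units; beyond the scatter). Compound 4 is estimated at 500 nM, range 150 nM to 1700 nM.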

Compound 4, half-maximal inhibitory concentration: 0.5 nM
Compound 4: middle estimate off by 1000-fold (3.00 log units), on the high side; the measured number lies below the stated range.
By their numbers in this assay, from the lowest: compound 4; then compound 1; then compound 2; then compound 3.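

In this assay this aromatic carbon proves far more responsive than the trifluoromethyl step suggested, with a 2200-fold lower number from compound 3 to compound 4 (3.35 log units; beyond the scatter) and also a 640-fold lower number from compound 2 to compound 4 (2.81 log units; beyond the scatter) in the same read-out. The outcome at this carbon therefore depends on the group: phenyl gives a large gain over hydrogen, whereas trifluoromethyl gives a modest loss. Nothing available here accounts for the gain. Open, as far as these compounds go, is whether a smaller ring such as cyclopropyl, a pyridyl ring or an amine at this carbon would keep the gain. Also open, from the compounds shown here alone, is whether phenyl here would do the same on the core of compound 1.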